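The source may hold more compounds than are shown below. What is called first, only, known or untested is meant among the compounds shown, and "the series" means these compounds.

Measured so far:
compound 1 `Cc1ccc(-c2nc3ccc(Br)cn3c2/C=N/OCc2cn(Cc3ccc(C#N)cc3)nn2)cc1`: 40 mg/kg
compound 2 `C#CCO/N=C/c1c(-c2ccc(C)cc2)nc2c(C)cccn12`: 20 mg/kg
compound 3 `Cc1cccn2c(/C=N/OCc3cn(Cc4ccc([N+](=O)[O-])cc4)nn3)c(-c3ccc(F)cc3)nc12`: 40 mg/kg

In a functional assay on the whole organism (strain NMRI) with Mus musculus as the target, with a stated time of 4 h (on this read-out higher numbers stand for an effect only at larger amounts of compound and lower numbers for an effect already at smaller amounts), compound 1 gives 40 mg/kg, level with compound 3 at the digits shown, the two together carrying the highest numbers of the three; the furthest, compound 2, gives 20 mg/kg, and even that gap stays within the scatter, so the three numbers cannot be ordered. Compound 4 `Cc1ccc(Cn2cc(CO/N=C/c3c(-c4ccc(C)cc4)nc4ccc(Br)cn34)nn2)cc1` differs from compound 1 in one place: methyl in place of cyano on an aromatic carbon. Going by the values given here, no step between two measured compounds covers this change, so nothing measured here speaks to its size. The expectation is of no step beyond the scatter, no change at the digits printed from compound 1 to compound 4 (within the scatter). Compound 4 is thus estimated at 40 mg/kg, with a range from 20 mg/kg to 80 mg/kg.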

Compound 4, minimum effective dose: 100 mg/kg
Compound 4: the middle estimate sits 2.5-fold (0.40 log units) below what was measured, outside the stated range (above it).
By their numbers in this assay, from the lowest: compounds 2, 1 and 3 (each within the scatter of the next); then compound 4.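

In this assay the change from 4-cyanobenzyl to 4-methylbenzyl gives a 2.5-fold higher number from compound 1 to compound 4 (0.40 log units; beyond the scatter), the only step shown that lies beyond the scatter. This position on the outer aromatic ring is therefore not indifferent to its group, and with the rest of compound 1 held fixed, the nitrile reads better than methyl by a modest margin. Nothing available bears on the reason for this step.

From the compounds shown here alone, whether the step carries over to other cores remains open, since it rests on a single pair. Going by these compounds, how an amine or a carboxylic acid would read at this place also remains open.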